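This account rests on a few compounds, and the source may have more. Where it says the series, first, only, none or still open, it means among the compounds named here.

Measured so far in the whole organism: compound 1 `O=C(NCCCOc1ccc2nc(O)ccc2c1)N(C1CC1)[C@@H]1CCCCC[C@H]1O` gave 0%; compound 2 `CN(C(=O)NCCCOc1ccc2nc(O)ccc2c1)[C@@H]1CCCC[C@H]1O` gave 10%; compound 3 `O=C(NCCCOc1ccc2nc(O)ccc2c1)N(C1CCCCCC1)[C@H]1CCCC[C@@H]1O` gave 11%.

All three were tested in a functional assay on the whole organism for inhibition, with Rattus norvegicus as the target, at a dose of 30 mg/kg by the oral route; a lower number here means less inhibition, a higher number more inhibition at the dose given (going by the name of the read-out). Compound 1 stands lowest of the three numbers. Compound 2 lies within the usual scatter of it, so no order between those two can be read. Compound 3 lies beyond the scatter, higher than compound 1. For the measured compounds named here, no step between two measured compounds that differ in a single place is at hand, so nothing about the size of any one change can be taken from these numbers. Compound 4 `O=C(NCCCOc1ccc2nc(O)ccc2c1)N(C1CC1)[C@H]1CCCC[C@H]1O` has not yet been measured. It differs from compound 1 in one place: 2-hydroxycyclohexyl in place of 2-hydroxycycloheptyl on an amide-type nitrogen. Because compound 1 gives 0% in the low region, the step from compound 1 to compound 4 is expected to be small and not beyond the scatter, a number 8 percentage points higher from compound 1 to compound 4 (within the scatter). Compound 4 is thus estimated at 8%, from 0% to 20%.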

Compound 4, a percentage reported as inhibition, in the whole organism at one dose (the size of the read-out at that dose, not a potency): 19%
Beside the measured number, compound 4's estimate is 11 percentage points below it; low and high end bracket the measured number.
By their numbers in this assay, from the lowest: compounds 1, 2, 3 and 4 (each within the scatter of the next, the first and the last beyond it).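

In this assay, for the compounds shown here, the change to 2-hydroxycyclohexyl in place of 2-hydroxycycloheptyl on the amide-type nitrogen gives a number 19 percentage points higher from compound 1 to compound 4 (beyond the scatter) and is the first single-place step available. It shows that the read-out at this dose responds to a six-membered ring in place of a seven-membered one at this position, though the step is modest. Nothing measured here explains the step.

From the compounds shown here alone, whether a 2-hydroxycyclopentyl group or an open-chain 2-hydroxyethyl group would go further remains open. So does whether the hydroxyl is needed at all, which a plain cyclohexyl group would test.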